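Adding a fluoro group to the anilino ring of compound 3

The source may report more compounds than this note shows. Statements on the series, on what has been measured and on what is new or still open speak of the compounds shown alone.

Of the compounds shown here, three of a shared core have been measured. Compound 1 `CCc1cccc(NC(=O)CSc2nc(Nc3ccccc3)c3ccccc3n2)c1`, compound 2 `COc1cccc(NC(=O)CSc2nc(Nc3ccccc3)c3ccccc3n2)c1` and compound 3 `C=CC(=O)Nc1cccc(NC(=O)CSc2nc(Nc3cccc(Cl)c3)c3ccccc3n2)c1` all carry the same amide-linked thioether on one side and an arylamino group on the other. In a functional assay on MGC-803 cells (Homo sapiens) for inhibition, read by MTT assay, with a stated time of 72 h (on this read-out lower numbers stand for stronger inhibition and higher numbers for weaker inhibition), compound 1 gives 15800 nM, compound 2 gives 10000 nM, and compound 3 gives 7830 nM. Compound 3 has the lowest number of the three, but its gap to compound 2 and its gap to compound 1 both lie within the scatter, so no order among them can be claimed. Among the measured compounds shown here, the only single-point step, a 1.6-fold lower number from compound 1 to compound 2 (0.20 log units; within the scatter), concerns the amide-side ring and was within the scatter.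

Compound 4 `C=CC(=O)Nc1cccc(NC(=O)CSc2nc(Nc3ccc(F)c(Cl)c3)c3ccccc3n2)c1` differs from compound 3 by fluoro in place of hydrogen on an aromatic carbon, the change sitting on an aromatic carbon of a six-membered aromatic ring of carbon only, ortho to a chloro group and para to a large group. For the measured compounds named here, no measured step touches this ring, so the only guide is the flatness of the existing numbers. The expected step, a 1.1-fold lower number from compound 3 to compound 4 (0.05 log units; within the scatter), is therefore none beyond the scatter. Compound 4 is estimated at 7000 nM, with a range from 3000 nM to 16000 nM.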

Compound 4, half-maximal inhibitory concentration: 7850 nM
For compound 4 the middle estimate is 1.1-fold (0.05 log units) below the measured one; the measured number falls inside the stated range.
By their numbers in this assay, from the lowest: compounds 3, 4, 2 and 1 (each within the scatter of the next).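

Going from a 3-chlorophenyl to a 3-chloro-4-fluorophenyl group gives the first measured step on this ring: in this assay there is a 1.0-fold higher number from compound 3 to compound 4 (0.00 log units; within the scatter). A single fluoro group at this place, ortho to a chloro group and para to a large group, therefore brings no difference beyond the scatter. No measurement shown here accounts for this result.

The compounds shown leave open whether this place would stay as flat with a bigger or charged group, such as a carboxylic acid or a dimethylamino group, in place of the fluoro group. They also leave open whether the fluoro group would give the same result on a ring without the chloro group, since here it was tested only alongside that group.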